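This account rests on a few compounds, and the source may have more. Where it says the series, first, only, none or still open, it means among the compounds named here.

Compound 1 `COc1ccc(C#N)cc1CSc1nc2cc(NC(=O)C3CC3)ccc2n1C(C)C`: in an assay on isolated protein for inhibition of Gonadotropin-releasing hormone receptor (Rattus norvegicus) (on this read-out lower numbers stand for stronger inhibition and higher numbers for weaker inhibition), compound 1 gives > 10000 nM, which is a limit of the assay and not a number.
Compound 2 `COc1ccc([N+](=O)[O-])cc1CSc1nc2cc(NC(=O)C3CCC3)ccc2n1C(C)C`: in this assay compound 2 gives 630 nM.

Among the measured compounds shown here, compound 2 thus stands on the only number in this assay. The other value shown is the limit of > 10000 nM in this assay, at which 1 of the 2 values shown sits. Compound 3 `COc1ccc([N+](=O)[O-])cc1CSc1nc2cc(NC(=O)NC3CC3)ccc2n1C(C)C` is not yet measured; it differs from compound 2 by cyclopropylamino in place of cyclobutyl on a carbonyl carbon. For the measured compounds named here, no measured step guides this change, so only a modest shift toward weaker inhibition, near the scatter, is expected. Compound 3 is expected to give 1000 nM, ranging from 300 nM to 4000 nM. The expected step is a 1.6-fold higher number from compound 2 to compound 3 (0.20 log units; within the scatter).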

Compound 3, half-maximal inhibitory concentration: 1600 nM
Estimate against measurement, compound 3: 1.6-fold (0.20 log units) below; low and high end bracket the measured number.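

In this assay, cyclopropylamino in place of cyclobutyl on a carbonyl carbon gives a 2.5-fold higher number from compound 2 to compound 3 (0.40 log units; beyond the scatter). This position therefore accepts a urea-type (cyclopropylcarbamoyl)amino group with a modest loss, and compound 3 still gives a number, while the one other value shown is a limit: the limit of > 10000 nM in this assay, at which 1 of the 3 values shown sits.

The step swaps the ring and brings in the amino nitrogen together, so the two changes cannot be separated. From the compounds shown here alone, how an open-chain ethylamino group or a morpholine on this carbonyl carbon would read remains open.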